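The source may report more compounds than this note shows. Statements on the series, on what has been measured and on what is new or still open speak of the compounds shown alone.

Working notes on the series. Among the measured compounds shown here, in a functional assay on MOLT-4 cells (Homo sapiens) for antiproliferative activity, read by MTT assay, with a stated time of 48 h (a higher number here means a weaker inhibitor, a lower number a stronger inhibitor), compound 1 `O=C(CCCCCCn1cc(Nc2ncc(Cl)c(Nc3cccc(Cl)c3)n2)cn1)NO` gives 130 nM and compound 2 `COc1ccc(Nc2nc(Nc3cnn(CCCCCCC(=O)NO)c3)ncc2Cl)cc1` gives 170 nM, so compound 1 stands level with its only measured neighbour. Compound 3 `O=C(CCCCCn1cc(Nc2ncc(Cl)c(Nc3cccc(Cl)c3)n2)cn1)NO` keeps the core of compound 1 and differs only in the chain: hydroxycarbamoyl in place of (hydroxycarbamoyl)methyl on a saturated chain carbon, five bonds along the chain from an aromatic nitrogen. In words, hydroxycarbamoyl stands in place of (hydroxycarbamoyl)methyl on a saturated chain carbon. For the measured compounds named here, the one measured step, a 1.3-fold higher number from compound 1 to compound 2 (0.12 log units; within the scatter), lies within the scatter, but it exchanges 3-chlorophenyl for 4-methoxyphenyl and leaves the chain untouched. Going by the values given here, it therefore bears only indirectly on this change, and no measured step shows what the chain does in this assay. The expected change is no shift beyond the scatter, and the estimated step is a 1.5-fold higher number from compound 1 to compound 3 (0.19 log units; within the scatter). For compound 3 the estimated value is 200 nM, with an expected range of 70 nM to 600 nM.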

Compound 3, half-maximal inhibitory concentration: 80 nM
The estimate for compound 3 lay 2.5-fold (0.40 log units) above the measured number; the measured number falls inside the stated range.
By their numbers in this assay, from the lowest: compounds 3, 1 and 2 (each within the scatter of the next, the first and the last beyond it).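

Among the compounds shown here, this is the first measured step at the chain: in this assay, hydroxycarbamoyl in place of (hydroxycarbamoyl)methyl, five bonds along the chain from an aromatic nitrogen, gives a 1.6-fold lower number from compound 1 to compound 3 (0.21 log units; within the scatter) and so leaves the number within the scatter. On the core of compound 1, the shorter chain of compound 3 therefore holds the antiproliferative activity, which the step at the aryl group could not show. Nothing at hand offers an explanation for this result.

Still open, as far as these compounds go, is whether a longer chain, or a shorter one such as 2-(hydroxycarbamoyl)ethyl, also stays within the scatter, and whether a carboxylic acid can stand in place of hydroxycarbamoyl. Also open, from the compounds shown here alone, is whether the same chain change gives a similar step with 4-methoxyphenyl in place of 3-chlorophenyl.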